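The compounds below may be only part of what the source reports. "The series", "measured", "known", "first", "only" and "open" are said of these compounds alone.

In a physicochemical assay for metabolic stability, read by LC-MS, in simulated gastric fluid, with a stated time of 15 min, tested at 50 uM (on this read-out higher numbers stand for a more stable compound and lower numbers for a less stable compound), the measured compounds are:
Compound 1 `CCC(=O)c1ccccc1OC(=O)c1coc(-c2ccccc2)n1`: 1.8%
Compound 2 `Cc1cccc(OC(=O)c2coc(-c3ccccc3)n2)c1C`: 2%
Compound 3 `CCC(C)c1ccccc1OC(=O)c1coc(-c2ccccc2)n1`: 0.2%

Compound 3 stands within the scatter of both other compounds, so the three cannot be ranked. Compound 4 `Cc1ccccc1OC(=O)c1coc(-c2ccccc2)n1` carries methyl in place of sec-butyl on an aromatic carbon, ortho to a large group (methyl in place of sec-butyl on an aromatic carbon). Among the compounds with values here, one measured step bears on this change: a number 1.6 percentage points lower from compound 1 to compound 3 (within the scatter), with sec-butyl in place of propanoyl on an aromatic carbon. Because a number 1.6 percentage points lower from compound 1 to compound 3 (within the scatter) stayed so small, no step beyond the scatter is expected. The expected change is a number 1.8 percentage points higher from compound 3 to compound 4 (within the scatter). For compound 4 the estimate is 2%, with an expected range from 0.3% to 10%.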

Compound 4, percent of the compound remaining: 1.5%
Estimate against measurement, compound 4: 0.5 percentage points above, within the range that was stated.
By their numbers in this assay, from the lowest: compounds 3, 4, 1 and 2 (each within the scatter of the next).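

In this assay, methyl in place of sec-butyl on the aromatic carbon gives a small step (a number 1.3 percentage points higher from compound 3 to compound 4 (within the scatter)). Hydrogen in place of methyl (a number 0.5 percentage points lower from compound 2 to compound 4 (within the scatter)) and methyl in place of propanoyl (a number 0.3 percentage points lower from compound 1 to compound 4 (within the scatter)) also stay within the scatter, so none of these changes separates the compounds. No measurement available here explains these results. From the compounds shown here alone, it remains open whether an amine or a carboxylic acid on this aromatic carbon would give a step beyond the scatter.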